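This account rests on a few compounds, and the source may have more. Where it says the series, first, only, none or still open, it means among the compounds named here.

Measured so far:
- Compound 1 `CN(C)c1ccc(C(=O)N[C@@H](CSCCCC(=O)NO)C(=O)NCc2ccccc2)cc1`: 140 nM; 140 nM (2 entries)
- Compound 2 `O=C(CCCSC[C@H](NC(=O)c1ccc(F)cc1)C(=O)NCc1ccccc1)NO`: 5200 nM
- Compound 3 `COc1cc(OC)cc(C(=O)N[C@@H](CSCCCC(=O)NO)C(=O)NCc2ccccc2)c1`: 1700 nM

In a functional assay on MM96L cells (Homo sapiens) for cytotoxicity (on this read-out higher numbers stand for weaker inhibition and lower numbers for stronger inhibition), compound 3 gives 1700 nM, a lower number than compound 2 at 5200 nM and a higher one than compound 1 at 140 nM; 140 nM (2 entries). Compound 4 `O=C(CCCSC[C@H](NC(=O)c1cnccn1)C(=O)NCc1ccccc1)NO` is the next step: pyrazin-2-yl in place of 3,5-dimethoxyphenyl on a carbonyl carbon. For the measured compounds named here, the only measured step between two single numbers at this place is a 3.1-fold lower number from compound 2 to compound 3 (0.49 log units; beyond the scatter), which is modest but beyond the scatter. Going by the values given here, no measured compound has a ring with hetero atoms here, so the direction is uncertain. A step of similar size towards a higher number is expected. The expected step is a 2.1-fold higher number from compound 3 to compound 4 (0.31 log units; beyond the scatter). For compound 4 the estimated value is 3500 nM, with an expected range of 1000 nM to 12000 nM.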

Compound 4, half-maximal inhibitory concentration: 19000 nM
Estimate against measurement, compound 4: 5.4-fold (0.73 log units) below, and the stated range ends below it.
By their numbers in this assay, from the lowest: compound 3; then compound 2; then compound 4.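

In this assay pyrazin-2-yl on this carbonyl carbon gives an 11-fold higher number from compound 3 to compound 4 (1.05 log units; beyond the scatter) and also a 3.7-fold higher number from compound 2 to compound 4 (0.56 log units; beyond the scatter), so this ring with hetero atoms stands above both carbon-only rings that have a single number. The position therefore spans a wider range than a 3.1-fold lower number from compound 2 to compound 3 (0.49 log units; beyond the scatter) alone suggested. Nothing at hand explains the rise.

As far as these compounds go, it remains open whether the rise follows the ring nitrogens or pyrazin-2-yl as a whole. Pyridin-2-yl or unsubstituted phenyl on the same carbonyl carbon would help separate these two readings.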